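A few compounds are considered here, and "the series" means these few. Any claim that something is new, unique, unknown or untested is made for them only; others in the source may bear on it.

Of the compounds shown here, three built on a shared core have been measured in a functional assay (B cells) with Mus musculus as the target; a lower number here means that less compound is needed, a higher number that more compound is needed for the effect. Compound 1 `Nc1nc(O)c2c(n1)n(C1OC(CO)[C@@H](O)[C@H]1O)c(=O)n2Cc1ccc([N+](=O)[O-])cc1` gives 40 uM in this assay. For the measured compounds named here, compound 2 `C=CCn1c(=S)n(C2OC(COC(C)=O)[C@H]3OC(C)(C)O[C@@H]23)c2nc(N)nc(O)c21` gives 50 uM, a number that lies within the scatter of the one for compound 1, so these two cannot be told apart. Compound 3 `C=CCn1c(=O)n([C@@H]2O[C@H](CO)[C@H]3OC(CCC)(CCC)O[C@H]32)c2nc(N)nc(O)c21` gives 4 uM, which sits beyond the scatter from compound 1. Compound 1 therefore stands among the higher numbers of this small set, with compound 3 the one that stands apart from it. Going by the values given here, no pair among the three differs in a single place, so no single-change step is available.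

Compound 4 `Nc1nc(O)c2c(n1)n(C1OC(CO)[C@@H](O)[C@H]1O)c(=O)n2C/C=C/c1ccccc1` has not yet been measured. It differs from compound 1 in one place: 2-phenylethenyl in place of 4-nitrophenyl on a saturated chain carbon bound to an aromatic nitrogen. The aromatic ring and the double bond outside it remain, while the two hydrogen-bond acceptors of the leaving group are gone. Among the compounds with values here, nothing among the measured compounds isolates this kind of change, so the step is expected to be modest, possibly in either direction, and quite likely within the scatter. Compound 4 is expected to give about 30 uM in this assay, with a range from 8 uM to 120 uM. This estimate amounts to a step of a 1.3-fold lower number from compound 1 to compound 4 (0.12 log units; within the scatter).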

Compound 4, concentration for half-maximal effect: 103 uM
For compound 4 the middle estimate is 3.4-fold (0.54 log units) below the measured one; measured number inside the range.
By their numbers in this assay, from the lowest: compound 3; then compounds 1 and 2 (each within the scatter of the next); then compound 4.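

In this assay, placing 2-phenylethenyl in place of 4-nitrophenyl on a saturated chain carbon bound to an aromatic nitrogen gives a 2.6-fold higher number from compound 1 to compound 4 (0.41 log units; beyond the scatter). For the compounds shown here, as the first single-place change in this set, it shows that the number responds to the group at this position, even though both groups carry one six-membered aromatic ring and one double bond outside it. Nothing at hand speaks to why the number moves.

Going by these compounds alone, with only this pair, the effect of removing the nitro group cannot be separated from the effect of inserting the two-carbon link between the ring and the chain carbon. Going by these compounds, it also remains open how an unsubstituted phenyl, a 4-aminophenyl or a 4-methoxyphenyl in the same place would read.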